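Trifluoromethyl for trifluoromethoxy at the urea aryl terminus

A few compounds are considered here, and "the series" means these few. Any claim that something is new, unique, unknown or untested is made for them only; others in the source may bear on it.

Measured so far:
compound 1, `COc1cc(-c2nc3ccc(Cl)cn3c2NC2CCCCC2)ccc1OCCCNC(=O)Nc1ccc(C(F)(F)F)cc1`: 336 nM
compound 2, `COc1cc(-c2nc3ccc(F)cn3c2NC2CCCCC2)ccc1OCCCNC(=O)Nc1ccc(OC(F)(F)F)cc1`: 696 nM

In an assay for inhibition of Polyunsaturated fatty acid 5-lipoxygenase (Homo sapiens), read by HPLC, with a stated time of 15 min (on this read-out lower numbers stand for stronger inhibition and higher numbers for weaker inhibition), compound 2 gives 696 nM, the higher of the two numbers; compound 1 sits lower at 336 nM, a gap beyond the usual scatter. Compound 1 and compound 2 differ in two places, so nothing separates the contribution of either place from these two values alone.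

Compound 3, `COc1cc(-c2nc3ccc(F)cn3c2NC2CCCCC2)ccc1OCCCNC(=O)Nc1ccc(C(F)(F)F)cc1`, keeps the core of compound 2 and changes only the terminal aryl substituent: trifluoromethyl in place of trifluoromethoxy on an aromatic carbon. Among the compounds with values here, compound 3 therefore differs from compound 1 in only one place, yet no measured step isolates either change. Within the data shown here, with no single-point step to lean on, a modest shift toward a lower number is expected from compound 2 to compound 3, a 1.5-fold lower number from compound 2 to compound 3 (0.19 log units; within the scatter), of a size that may still fall within the scatter. Compound 3 is estimated at 450 nM, with a range of 200 nM to 1000 nM.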

Compound 3, half-maximal inhibitory concentration: 649 nM
The estimate for compound 3 lay 1.4-fold (0.16 log units) below the measured number; the range from low to high includes it.
By their numbers in this assay, from the lowest: compounds 1, 3 and 2 (each within the scatter of the next, the first and the last beyond it).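

In this assay trifluoromethyl in place of trifluoromethoxy on this aromatic carbon gives a 1.1-fold lower number from compound 2 to compound 3 (0.03 log units; within the scatter) and so, with the fluoro substituent on the core held fixed, this exchange at the urea aryl terminus leaves the number within the scatter. With the 4-(trifluoromethyl)phenyl terminus held fixed, fluoro in place of chloro gives a 1.9-fold higher number from compound 1 to compound 3 (0.29 log units; within the scatter) and is also within the scatter, so neither single change, read alone, shows a difference beyond it. Nothing at hand bears on the cause of either step.

On these data alone, whether the trifluoromethyl and trifluoromethoxy exchange reads the same with chloro on the core remains open. Also open, as far as these compounds go, is how this aromatic carbon tolerates groups of another kind, such as a carboxylic acid, an amine or a nitrile.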